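A few compounds are considered here, and "the series" means these few. Any claim that something is new, unique, unknown or untested is made for them only; others in the source may bear on it.

Measured in a functional assay on A-375 cells (Homo sapiens) for inhibition, read by CCK-8 assay, with a stated time of 72 h, tested at 2 uM; a lower number here means less inhibition of growth, a higher number more inhibition of growth at the concentration tested:
compound 1 `CCc1ccc(SCc2ccc(/C=C/C(=O)Nc3ccccc3N)cc2)cc1`: 5.27%
compound 2 `Cc1ccc(SCc2ccc(C(=O)Nc3ccccc3N)cc2)cc1`: 17.5%
compound 3 `COc1ccc(SCc2ccc(C(=O)Nc3ccccc3N)cc2)cc1OC`: 18.1%

In this assay, compound 2 gives 17.5%, which is within the scatter of compound 3 at 18.1%. Compound 1, at 5.27%, lies beyond the scatter below compound 2.

The next compound to be tested is compound 4 `Nc1ccccc1NC(=O)c1ccc(CSc2ccc(Cl)cc2)cc1`. It differs from compound 2 by chloro in place of methyl on an aromatic carbon, para to a large group. Within the data shown here, no measured step isolates this change, so the expectation rests on indirect evidence. Compared with compound 2, compound 3 carries other groups on that ring and gives 18.1%, within the scatter of compound 2. A small change is therefore expected, with a slight rise as the likelier direction and nothing beyond the scatter. The estimated step is a number 2.5 percentage points higher from compound 2 to compound 4 (within the scatter). The expected value for compound 4 is 20%, with an estimated range of 8% to 36%.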

Compound 4, percent growth inhibition at one concentration: 25.3%
Compound 4: middle estimate off by 5.3 percentage points, on the low side; the range from low to high includes it.
By their numbers in this assay, from the lowest: compound 1; then compounds 2, 3 and 4 (each within the scatter of the next).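

In this assay, chloro in place of methyl on an aromatic carbon, para to a large group, gives a number 7.8 percentage points higher from compound 2 to compound 4 (within the scatter). Among these compounds, this is the first measured step in which a single group changes at this position, since compound 3 carries other groups on that ring, and it shows that replacing 4-methylphenyl with 4-chlorophenyl leaves the reading within the scatter. No independent measurement bears on this step.

From the compounds shown here alone, whether an amine, a carboxylic acid or a methoxy group alone at this same position would move the number beyond the scatter remains open. Steps involving compound 1 cannot be read, as it differs from the other compounds in more than one place, so its lower value of 5.27% cannot be assigned to any one change.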